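Selenocyanate Carbamates: Removing a Chloro Substituent

This account rests on a few compounds, and the source may have more. Where it says the series, first, only, none or still open, it means among the compounds named here.

Measured compounds:
Compound 1 `CCCCCCOC(=O)Nc1ccc([Se]C#N)cc1` — 17300 nM
Compound 2 `N#C[Se]c1ccc(NC(=O)Oc2ccc(Cl)cc2)cc1` — 6400 nM

Two aryl selenocyanate carbamates have been tested in a functional assay on PC-3 cells (Homo sapiens) for cytotoxicity, read by MTT assay, with a stated time of 72 h; on this read-out higher numbers stand for weaker inhibition of growth and lower numbers for stronger inhibition of growth. Compound 1 carries a hexyl carbamate, and in this assay compound 1 gives 17300 nM. Compound 2 carries an aryl carbamate bearing a chloro group, and in this assay compound 2 gives 6400 nM. Of the two numbers, compound 2 has the lower one; compound 1 lies higher by a margin that is beyond the usual scatter, so on these two values compound 2 inhibits growth more strongly.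

Compound 3 `N#C[Se]c1ccc(NC(=O)Oc2ccccc2)cc1` follows from compound 2 by a single change: hydrogen in place of chloro on an aromatic carbon, para to a large group. Among the measured compounds shown here, no comparable pair among the measured compounds shows the size of such a step, so the expectation rests on the change alone. Since the chloro group is the only part removed and nothing enters beyond a hydrogen atom, the expected step is small, if anything toward a somewhat higher number, and is estimated as a 1.4-fold higher number from compound 2 to compound 3 (0.15 log units; within the scatter). Compound 3 is thus expected to give about 9000 nM, with a range from 4000 nM to 20000 nM.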

Compound 3, concentration for 50% growth inhibition: 9100 nM
The estimate for compound 3 lay 1.0-fold (0.00 log units) below the measured number; low and high end bracket the measured number.
By their numbers in this assay, from the lowest: compounds 2, 3 and 1 (each within the scatter of the next, the first and the last beyond it).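

In this assay, among the compounds shown here, taking the chloro group off the aromatic carbon, para to a large group, gives a 1.4-fold higher number from compound 2 to compound 3 (0.15 log units; within the scatter) and thereby isolates this position for the first time, since the earlier compounds differed in more than one place; on this single step, the chloro group is not needed to keep the growth inhibition seen with compound 2. For the compounds shown here, compound 3 also supplies the first single step on the carbamate oxygen, where phenyl in place of hexyl gives a 1.9-fold lower number from compound 1 to compound 3 (0.28 log units; within the scatter), so that an aromatic ring and an open chain on this oxygen cannot be told apart in this cell assay, and neither single change on its own reaches beyond the scatter. The data offer no measured property of these compounds that could explain the size of either step. The compounds shown leave open what a fluoro, methoxy or amino group would do in place of the chloro group on that same ring carbon, and whether a chloro group elsewhere on the ring would read the same. They also leave open how a benzyl group or a longer chain on the carbamate oxygen would compare with phenyl and hexyl.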